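The source may report more compounds than this note shows. Statements on the series, on what has been measured and on what is new or still open speak of the compounds shown alone.

In a functional assay on ACHN cells (Homo sapiens) for antiproliferative activity, read by MTT assay, with a stated time of 96 h (a higher number here means a weaker inhibitor, a lower number a stronger inhibitor), compound 1 `O=C1NC(=O)C2(CSC3=C2C(=O)c2ncccc2C3=O)N1` gives 80 nM, and compound 2 `CCCCc1ccc(N2C(=O)NC3(CSC4=C3C(=O)c3ncccc3C4=O)C2=O)cc1`, which carries a 4-butylphenyl in place of hydrogen on an amide-type nitrogen in a ring, gives 50 nM. These two numbers lie within the scatter of each other, so the data do not separate the two compounds.

Compound 3 `CC(C)(C)c1ccc(N2C(=O)NC3(CSC4=C3C(=O)c3ncccc3C4=O)C2=O)cc1` keeps the shared core and the phenyl ring of compound 2 and alters only the chain: tert-butyl in place of butyl on an aromatic carbon. This places tert-butyl in place of butyl on an aromatic carbon, and the group becomes 4-(tert-butyl)phenyl.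

Among the measured compounds shown here, only one measured step bears on this change, a 1.6-fold lower number from compound 1 to compound 2 (0.20 log units; within the scatter), and it stays within the scatter even though the whole 4-butylphenyl enters there. For the measured compounds named here, no measured pair varies the chain itself, so this evidence is indirect. On that basis, no step beyond the scatter is expected in this assay, in either direction. The estimated step of no change at the digits printed from compound 2 to compound 3 (within the scatter) is expected to remain within the scatter. For compound 3 the estimated value is 50 nM, with an expected range of 20 nM to 130 nM.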

Compound 3, half-maximal inhibitory concentration: 150 nM
Beside the measured number, compound 3's estimate is 3.0-fold (0.48 log units) below it; measured number outside the range, above it.
By their numbers in this assay, from the lowest: compounds 2, 1 and 3 (each within the scatter of the next, the first and the last beyond it).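

In this assay, the exchange of butyl for tert-butyl on an aromatic carbon, para to a large group, gives the first step shown that lies beyond the scatter (a 3.0-fold higher number from compound 2 to compound 3 (0.48 log units; beyond the scatter)). The two groups count the same carbon atoms and differ only in how these are joined, so this position separates two chains of identical composition, which the earlier step, with the whole 4-butylphenyl entering, could not show. The 4-(tert-butyl)phenyl group in place of hydrogen still stays within the scatter (a 1.9-fold higher number from compound 1 to compound 3 (0.27 log units; within the scatter)), so the difference appears only between the two chains and not against the parent, and nothing measured here accounts for it.

The compounds shown leave open whether the step follows branching in general or belongs to these two groups alone, a question that isopropyl, propyl or a longer chain such as hexyl at the same place could address. They also leave open how a group of another kind, such as an amine or a carboxylic acid, would behave there.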